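From difluorophenyl to methylpyridinyl on the sulfonyl sulfur

This account rests on a few compounds, and the source may have more. Where it says the series, first, only, none or still open, it means among the compounds named here.

Compound 1 (`O=C(NCc1ccc(S(=O)(=O)c2cc(F)cc(F)c2)cc1)c1cc2ccncc2o1`) stands at the low end of the numbers in a physicochemical assay for solubility, measured as kinetic solubility, with a stated time of 24 h, at pH 7.4 (a higher number here means a more soluble compound, a lower number a less soluble compound), where compound 1 gives 5900 nM in a single entry. Compound 2 (`CC(C)N1CCC([S+]([O-])c2ccc(CNC(=O)c3cc4ccncc4o3)cc2)CC1`) gives 153000 nM; 167000 nM; 175000 nM (3 entries) and was measured repeatedly, with close agreement (the several entries of compound 2 in this assay, 153000 nM; 167000 nM; 175000 nM (3 entries)). Compound 3 (`O=C(NCc1ccc([S+]([O-])C2CCN(C3CCOCC3)CC2)cc1)c1cc2ccncc2o1`) gives 156000 nM and holds the nearest single number, far above compound 1 and well beyond the scatter.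

Compound 4 (`Cc1ccc(S(=O)(=O)c2ccc(CNC(=O)c3cc4ccncc4o3)cc2)cn1`) keeps the core of compound 1 and changes one group: 6-methylpyridin-3-yl in place of 3,5-difluorophenyl on a sulfonyl sulfur. An aromatic ring of carbon only leaves, and an aromatic ring with a hetero atom enters.

Among the compounds with values here, no two measured compounds differ in one place, so this change has no direct precedent in the data. An upward step beyond the scatter is expected, though one that covers only part of the gap to compound 3, which stands at 156000 nM in this comparison. The expected step is a 4.2-fold higher number from compound 1 to compound 4 (0.63 log units; beyond the scatter) in this assay. For compound 4 the estimated value is 25000 nM, with an expected range from 9000 nM to 70000 nM.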

Compound 4, solubility: 47000 nM
Compound 4: middle estimate off by 1.9-fold (0.27 log units), on the low side; the measured number falls inside the stated range.
By their numbers in this assay, from the lowest: compound 1; then compound 4; then compound 3.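

Within the data shown here, this is the first comparison in this assay between compounds that differ in one place, and it shows that the group on the sulfonyl sulfur matters to this read-out: the number moves an 8.0-fold higher number from compound 1 to compound 4 (0.90 log units; beyond the scatter) when 6-methylpyridin-3-yl takes the place of 3,5-difluorophenyl. The step comes with no net charge on either group, as an aromatic ring of carbon only leaves and an aromatic ring with a hetero atom enters, so a clear rise at this position does not need a charged group to enter. The step can be read against repeats in this read-out that agree closely: the several entries of compound 2 in this assay, 153000 nM; 167000 nM; 175000 nM (3 entries).

The exchange removes both fluorine atoms and brings in the ring nitrogen and the methyl group together, so the compounds shown do not tell which of these changes carries the step, and compound 2 and compound 3 differ from compound 1 in more than one place and cannot settle it. A plain pyridin-3-yl group without the methyl, or a phenyl ring bearing a single fluorine, on the same sulfonyl sulfur would begin to separate these changes.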